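A few compounds are considered here, and "the series" means these few. Any claim that something is new, unique, unknown or untested is made for them only; others in the source may bear on it.

Of the compounds shown here, two built on one shared core have been tested in a functional assay on C6 cells (Rattus norvegicus) for cytotoxicity, read by MTT assay, with a stated time of 24 h, tested at 100 ug/mL; a higher number here means a weaker effect of the compound at the concentration tested, a lower number a stronger effect. In this assay compound 2 `Cn1cnnc1SCC(=O)N/N=c1/scc(-c2ccccc2)n1-c1ccccc1` gives 38.6%, and compound 1 `O=C(CSc1nnnn1-c1ccccc1)N/N=c1/scc(-c2ccc(F)cc2)n1-c1ccccc1` gives 35.8%. Compound 2 stands at the top of these two numbers, but its gap to compound 1 lies within the usual scatter of the measurement, so the two cannot be told apart on this evidence. Both leave a large share of the cells alive at the concentration used, which means a weak effect.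

Compound 3 `O=C(CSc1nnnn1-c1ccccc1)N/N=c1/scc(-c2ccccc2)n1-c1ccccc1` has not yet been measured in this assay. It differs from compound 2 in one place: 1-phenyl-1H-tetrazol-5-yl in place of 4-methyl-4H-1,2,4-triazol-3-yl on a sulfur. For the measured compounds named here, no pair of measured compounds shows how a change of this kind moves the read-out, so there is no measured step to lean on. The expectation is that the step from compound 2 to compound 3 a number 1.6 percentage points lower from compound 2 to compound 3 (within the scatter) is small, with no direction beyond the scatter. Compound 3 is therefore estimated at 37%, with a likely range from 25% to 50%.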

Compound 3, a percentage reported as activity, at one concentration (the size of the read-out at that concentration, not a potency): 35.8%
Compound 3: the middle estimate sits 1.2 percentage points above what was measured; the range from low to high includes it.
By their numbers in this assay, from the lowest: compounds 1, 3 and 2 (each within the scatter of the next).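

Replacing 4-methyl-4H-1,2,4-triazol-3-yl with 1-phenyl-1H-tetrazol-5-yl on the sulfur gives a number 2.8 percentage points lower from compound 2 to compound 3 (within the scatter) in this assay, so this position accepts a larger group with an extra carbon-only aromatic ring without a read-out that can be told apart. Compound 3 also links compound 1 and compound 2, which differ in two places, through single changes: hydrogen in place of fluoro on an aromatic carbon gives no change at the digits printed from compound 1 to compound 3 (within the scatter) and so this assay does not separate the fluoro compound from its parent. No measurement at hand explains why either change leaves the read-out within the scatter.

As far as these compounds go, all three compounds sit close together, so it remains open whether any group on this sulfur can shift the read-out beyond the scatter, and a plain ethyl chain or an aromatic ring carrying an amine or a carboxylic acid would test that. On the aromatic ring that carries the fluoro in compound 1, only fluoro and hydrogen can be compared, which leaves groups such as chloro or methoxy open.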